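Working notes on the series: expectation for compound 4

The source may hold more compounds than are shown below. What is called first, only, known or untested is meant among the compounds shown, and "the series" means these compounds.

Measured compounds:
compound 1 `COc1ccc(-c2[nH]c3ccccc3c2/C=C(\C#N)S(=O)(=O)c2ccccc2)cc1` – 203 nM
compound 2 `COc1ccc(-c2[nH]c3ccc(OC)cc3c2/C=C(\C#N)S(=O)(=O)c2ccccc2)cc1` – 276 nM
compound 3 `COc1ccc(-c2[nH]c3ccc(OC)cc3c2C=C(C#N)C#N)cc1` – 122 nM

All three numbers come from a functional assay on MDA-MB-435 cells (Homo sapiens) for inhibition, read by sulforhodamine B assay, with a stated time of 48 h; a lower number here means a stronger inhibitor of growth, a higher number a weaker inhibitor of growth. Compound 2 has the highest of the three numbers. Its nearest neighbour is compound 1: the step of a 1.4-fold higher number from compound 1 to compound 2 (0.13 log units; within the scatter) is within the scatter, so the two compounds cannot be ordered. Among the compounds with values here, the furthest is compound 3, whose value in this assay lies beyond the scatter from compound 2; no single-point step links those two, so only the two values themselves can be compared.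

Compound 4 `COc1ccc2[nH]c(-c3ccccc3)c(/C=C(\C#N)S(=O)(=O)c3ccccc3)c2c1` is not yet measured. It differs from compound 2 in one place: hydrogen in place of methoxy on an aromatic carbon.

Within the data shown here, only one measured step bears on this change, and only loosely. It is the step from compound 1 to compound 2, a 1.4-fold higher number from compound 1 to compound 2 (0.13 log units; within the scatter), where a methoxy also leaves or enters on an aromatic carbon, though on a different ring of the shared core. That step stayed within the scatter. Nothing in the series tests the 4-methoxyphenyl group itself. The expectation is therefore that removing this methoxy changes the number little, if at all, beyond the scatter.

Compound 4 is estimated at 300 nM in this assay, with a range from 140 nM to 650 nM. This expected step from compound 2 is a 1.1-fold higher number from compound 2 to compound 4 (0.04 log units; within the scatter).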

Compound 4, concentration for 50% growth inhibition: 1100 nM
Estimate against measurement, compound 4: 3.7-fold (0.56 log units) below; measured number outside the range, above it.
By their numbers in this assay, from the lowest: compounds 3, 1 and 2 (each within the scatter of the next, the first and the last beyond it); then compound 4.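

In this assay, within the data shown here, the change from 4-methoxyphenyl to phenyl gives a 4.0-fold higher number from compound 2 to compound 4 (0.60 log units; beyond the scatter), so this methoxy, para to a large group, is the first methoxy whose removal moves the number beyond the scatter. The methoxy on a different ring of the shared core behaves otherwise, since the step of a 1.4-fold higher number from compound 1 to compound 2 (0.13 log units; within the scatter) stays within the scatter, and in this series the effect of a methoxy therefore cannot be read from one ring to the other. No measurement available here accounts for the weaker growth inhibition that follows removal of this methoxy.

The compounds shown leave open whether the methoxy itself is needed at this place or whether another group, such as hydroxy, ethoxy, fluorine or an amine, would hold the number near that of compound 2. They also leave open whether the same change carries over to the core without the second methoxy, or to compound 3, where two nitriles replace the nitrile and phenylsulfonyl pair.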